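The source may hold more compounds than are shown below. What is called first, only, known or untested is meant among the compounds shown, and "the series" means these compounds.

Measured in a physicochemical assay, with a stated time of 6 min; on this read-out lower numbers stand for stronger inhibition and higher numbers for weaker inhibition:
- compound 1 (`O=C(Nc1ccc(I)cc1)Nc1nc(-c2cc3ccccc3o2)cs1`) gives 62000 nM
- compound 2 (`COc1cccc(NC(=O)Nc2nc(-c3cc4ccccc4o3)cs2)c1`) gives 200 nM

Compound 2 holds the lower number of the two. Next comes compound 3 (`O=C(Nc1cccc(F)c1)Nc1nc(-c2cc3ccccc3o2)cs1`) with the change fluoro in place of methoxy on an aromatic carbon in which fluoro takes the place of methoxy on an aromatic carbon, meta to a large group. Among the measured compounds shown here, one measured step bears on this: a 310-fold lower number from compound 1 to compound 2 (2.49 log units; beyond the scatter) (large and beyond the scatter) with 3-methoxyphenyl in place of 4-iodophenyl. For the measured compounds named here, that step swapped both the group and its place, so it does not isolate the methoxy, and no measured compound carries fluoro. A much smaller step is expected in this assay toward a higher number, although a step within the scatter remains possible. The expected change is a 2.5-fold higher number from compound 2 to compound 3 (0.40 log units; beyond the scatter) in this estimate. For compound 3 the estimated value is 500 nM with an expected range from 100 nM to 3000 nM for the coming measurement.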

Compound 3, half-maximal inhibitory concentration: 4520 nM
Compound 3: middle estimate off by 9.0-fold (0.96 log units), on the low side; measured number outside the range, above it.
By their numbers in this assay, from the lowest: compound 2; then compound 3; then compound 1.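

In this assay, the change from 3-methoxyphenyl to 3-fluorophenyl gives a 23-fold higher number from compound 2 to compound 3 (1.35 log units; beyond the scatter) with the place on the ring held constant, the first read of the group alone at this aromatic carbon. The methoxy therefore holds a clear advantage over fluoro here, and the outcome at this carbon depends strongly on which of these two groups occupies it. The other new step, a 14-fold lower number from compound 1 to compound 3 (1.14 log units; beyond the scatter) with 3-fluorophenyl in place of 4-iodophenyl, again changes group and place together, and no data bear on the reason for either step.

On these data alone, whether a hydroxy, an ethoxy or an amine at this carbon would match the methoxy remains open. A 3-iodophenyl or 4-methoxyphenyl analogue would be needed to separate the effect of the group from that of its place on the ring.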